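Methyl in Place of Fluoro: Expected Outcome for Compound 3

This account rests on a few compounds, and the source may have more. Where it says the series, first, only, none or still open, it means among the compounds named here.

Compound 1, `c1ccc(-c2ccc3[nH]ncc3c2)cc1`, in an assay on CHO-TREX cells for antagonist activity at transient receptor potential cation channel subfamily A member 1 (Homo sapiens), read by FLIPR and calcium flux, with a stated time of 10 min (a lower number here means a stronger inhibitor, a higher number a weaker inhibitor), gives only a limit, > 30000 nM.
Compound 2, `Fc1ccccc1-c1ccc2[nH]ncc2c1`, in this assay gives 3950 nM.

Compound 2 thus holds the only number shown; the other value is a limit, (the limit of > 30000 nM in this assay, at which 1 of the 2 values shown sits). Compound 3, `Cc1ccccc1-c1ccc2[nH]ncc2c1`, differs from compound 2 by methyl in place of fluoro on an aromatic carbon. For the measured compounds named here, the one measured step, an at least 7.5-fold lower number from compound 1 to compound 2 (0.88 log units; beyond the scatter), shows what a fluoro in this place brought over hydrogen, but nothing measured shows methyl there. Compound 3 is therefore estimated at 5000 nM, between 1500 nM and 20000 nM. The expected step of a 1.3-fold higher number from compound 2 to compound 3 (0.10 log units; within the scatter) would stay within the scatter.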

Compound 3, half-maximal inhibitory concentration: 7810 nM
For compound 3 the middle estimate is 1.6-fold (0.19 log units) below the measured one; measured number inside the range.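

In this assay the change to methyl on this aromatic carbon gives a 2.0-fold higher number from compound 2 to compound 3 (0.30 log units; within the scatter) and so leaves the two groups level. Methyl in place of hydrogen gives an at least 3.8-fold lower number from compound 1 to compound 3 (0.58 log units; beyond the scatter) as well, so in this pair of compounds the gain over hydrogen is not confined to fluoro. As far as these compounds go, the full size of that gain stays unknown because compound 1 gives only a limit: the limit of > 30000 nM in this assay, at which 1 of the 3 values shown sits.

Open, from the compounds shown here alone, is whether an amine, a methoxy or a trifluoromethyl on this carbon would hold this level of inhibition. Also open, going by these compounds, is whether methyl or fluoro would do the same elsewhere on that ring.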